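Adding one methyl to compound 3

This account rests on a few compounds, and the source may have more. Where it says the series, first, only, none or still open, it means among the compounds named here.

Measured in an ADME assay on MDBK cells (Bos taurus) for cytotoxicity (on this read-out higher numbers stand for lower toxicity in this test and lower numbers for higher toxicity in this test), as follows:
- Compound 1 `Cc1ccn(Cc2c(F)cccc2F)c2nc(-c3c(F)cccc3F)nc1-2` gives > 100000 nM (a limit)
- Compound 2 `Fc1cccc(F)c1-c1nc2ccn(Cc3ccccc3)cc-2n1` gives > 100000 nM (a limit)
- Compound 3 `c1ccc(Cn2ccc3nc(-c4ccccc4)nc-3c2)cc1` gives > 100000 nM (a limit)

Compound 3 stands at > 100000 nM which is a limit of the assay and not a number. The whole set rests on the limit of > 100000 nM in this assay, at which 3 of the 3 values shown sit, and no exact value is known for any of these compounds.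

Compound 4 `Cc1cccc(Cn2ccc3nc(-c4ccccc4)nc-3c2)c1` differs from compound 3 by methyl in place of hydrogen on an aromatic carbon and by nothing else. Among the compounds with values here, since the one measured step is a step that the two limits leave unreadable from compound 2 to compound 3 and concerns a different group, no step beyond the usual scatter is expected in this assay for this change. The expected size is a number no higher from compound 3 to compound 4 (the limit leaves the size open) for this small addition. For compound 4 the estimated value is 100000 nM with an expected range from 40000 nM to 200000 nM and most likely only a limit will be reported.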

Compound 4, half-maximal cytotoxic concentration: > 100000 nM
Compound 4 was reported as a limit; the forecaster's own chance of this, stated with the estimate: 90%; the middle value sits exactly at the limit.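

No step can be read from compound 3 to compound 4 in this assay because both are reported only as a limit of the assay, not as a number: the limit of > 100000 nM in this assay, at which 4 of the 4 values shown sit.

The compounds shown leave open the exact value of each compound and whether the added methyl changes it at all.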